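Third halogenated benzyl variant on a shared core

The source may hold more compounds than are shown below. What is called first, only, known or untested is meant among the compounds shown, and "the series" means these compounds.

Measured so far:
Compound 1: `Clc1cccc(CSc2nnc(-c3ccc4c(c3)OCCO4)n2-c2ccccc2)c1` — 2390 nM
Compound 2: `Fc1ccc(CSc2nnc(-c3ccc4c(c3)OCCO4)n2-c2ccccc2)c(F)c1` — 1960 nM

In a functional assay on HepG2 cells (Homo sapiens) for antiproliferative activity, read by MTT assay, with a stated time of 24 h (on this read-out higher numbers stand for weaker inhibition and lower numbers for stronger inhibition), compound 1 gives 2390 nM and compound 2 gives 1960 nM. For the measured compounds named here, the only step between measured compounds, a 1.2-fold lower number from compound 1 to compound 2 (0.09 log units; within the scatter), swaps one halogenated phenyl for another on the saturated chain carbon bound to a sulfur and leaves the number essentially where it was; compound 2 and compound 1 therefore cannot be ranked against each other.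

Compound 3, `Brc1ccc(CSc2nnc(-c3ccc4c(c3)OCCO4)n2-c2ccccc2)cc1`, is not yet measured. It differs from compound 2 as follows:

4-bromophenyl in place of 2,4-difluorophenyl on a saturated chain carbon bound to a sulfur

Going by the values given here, only the step from compound 1 to compound 2 bears on this change: it also exchanged halogens on the same phenyl at the same place, and it stayed within the scatter. A further halogen exchange at that place is expected to behave alike, giving no step beyond the scatter in this assay, so that a 1.0-fold higher number from compound 2 to compound 3 (0.01 log units; within the scatter) is the expected outcome. Compound 3 is estimated at 2000 nM, with a likely range from 1000 nM to 4000 nM.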

Compound 3, half-maximal inhibitory concentration: 7940 nM
Compound 3: the middle estimate sits 4.0-fold (0.60 log units) below what was measured; measured number outside the range, above it.
By their numbers in this assay, from the lowest: compounds 2 and 1 (each within the scatter of the next); then compound 3.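

In this assay, the place on a saturated chain carbon bound to a sulfur no longer looks indifferent to the choice of halogenated phenyl: 2,4-difluorophenyl to 4-bromophenyl gives a 4.1-fold higher number from compound 2 to compound 3 (0.61 log units; beyond the scatter) and 3-chlorophenyl to 4-bromophenyl gives a 3.3-fold higher number from compound 1 to compound 3 (0.52 log units; beyond the scatter) and so separates compound 3 from the other two compounds, which remain within the scatter of each other. Exchanging one halogenated phenyl for another at this place is therefore not always silent, although both steps are only modest and point to weaker inhibition with 4-bromophenyl. Nothing available accounts for this difference.

The three groups differ together in the kind, number and placement of their halogens, so the compounds shown do not tell which of these goes with the step. An unsubstituted phenyl at the same place would show whether any halogen is needed at all, and a phenyl carrying a carboxylic acid would test a group of a wholly different kind.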